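Ester in Place of Hydrazide on a Sulfonamide Core

The compounds below may be only part of what the source reports. "The series", "measured", "known", "first", "only" and "open" are said of these compounds alone.

Measured compounds in a functional assay on the whole organism for inhibition, with Rattus norvegicus as the target, read by paw edema, with stated times of 30 min and 1 h, at a dose of 0.28 mmol/kg by the oral route; a higher number here means more inhibition at the dose given (going by the name of the read-out), a lower number less inhibition:
compound 1, `CC(=O)c1ccc(NC(=O)c2nc(-c3ccccc3)n(-c3ccc(S(N)(=O)=O)cc3)n2)cc1`, 53%
compound 2, `NS(=O)(=O)c1ccc(-n2nc(C(=O)NC3CCCCC3)nc2-c2ccccc2)cc1`, 20%
compound 3, `NNC(=O)c1nc(-c2ccccc2)n(-c2ccc(S(N)(=O)=O)cc2)n1`, 32%

All three share one core and differ only in the group carried on the amide-type nitrogen. Compound 3 stands second highest of the three numbers: compound 2 sits a number 12 percentage points higher from compound 2 to compound 3 (beyond the scatter), and compound 1 sits above it by a number 21 percentage points lower from compound 1 to compound 3 (beyond the scatter). The largest step seen is a number 33 percentage points lower from compound 1 to compound 2 (beyond the scatter).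

Compound 4 is `COC(=O)c1nc(-c2ccccc2)n(-c2ccc(S(N)(=O)=O)cc2)n1`. The change from compound 3 is methoxy in place of aminoamino on a carbonyl carbon. Going by the values given here, no measured step exchanges a group on the carbonyl carbon itself; the three steps all swap the group on the nitrogen. They show only that replacing the 4-acetylphenyl lowers this assay markedly, while the smaller groups amino and cyclohexyl differ from each other by a modest amount. This change removes both donors, so compound 4 is expected to fall, but only moderately: the estimated step is a number 8 percentage points lower from compound 3 to compound 4 (within the scatter). Compound 4 is therefore expected to give about 24%, within 8% to 42%.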

Compound 4, a percentage reported as inhibition, in the whole organism at one dose (the size of the read-out at that dose, not a potency): 38%
Beside the measured number, compound 4's estimate is 14 percentage points below it; low and high end bracket the measured number.
By their numbers in this assay, from the lowest: compound 2; then compounds 3 and 4 (each within the scatter of the next); then compound 1.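

In this assay, going by these compounds alone, the group on the carbonyl carbon itself is changed for the first time in this comparison: methoxy in place of aminoamino gives a number 6 percentage points higher from compound 3 to compound 4 (within the scatter) and so shows that, for this pair, taking away the hydrogen-bond donors of aminoamino leaves no readable change. Set against the two amides, the same methoxy gives a number 18 percentage points higher from compound 2 to compound 4 (beyond the scatter) when it replaces cyclohexylamino and a number 15 percentage points lower from compound 1 to compound 4 (beyond the scatter) when it replaces (4-acetylphenyl)amino, so a nitrogen on this carbonyl carbon is not required for inhibition at this dose, and the group on that nitrogen decides whether an amide stands under or over the ester. Nothing available here explains why the numbers fall this way.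

Still open, as far as these compounds go, is whether a carboxylic acid, an ethoxy group or a simple unsubstituted amide on the same carbonyl carbon would stay level with methoxy and aminoamino or break away from them. Also open, from the compounds shown here alone, is whether the acetyl group of the 4-acetylphenyl matters, which a plain phenyl amide on the shared core would test.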